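Hydroxy in Place of Chloro: Expected Tolerance

The source may hold more compounds than are shown below. What is called first, only, known or untested is meant among the compounds shown, and "the series" means these compounds.

Compound 1 `O=C(N/N=C/c1ccccc1)c1cccnc1` gives in an ADME assay on MT4 cells (Homo sapiens) for cytotoxicity, read by MTT assay, with a stated time of 4 days (a higher number here means that more compound is tolerated, a lower number that less compound is tolerated), only a limit of the assay: > 125 ug/mL
Compound 2 `O=C(N/N=C/c1cccc(Cl)c1)c1cccnc1` gives in this assay 62 ug/mL
Compound 3 `O=C(N/N=C/c1ccc(Br)cc1)c1cccnc1` gives in this assay 61 ug/mL

In this assay compound 2 and compound 3 give numbers that lie within the scatter of each other. Compound 1 reaches only the limit of the assay (the limit of > 125 ug/mL in this assay, at which 1 of the 3 values shown sits). Compound 4 `O=C(N/N=C/c1cccc(O)c1)c1cccnc1` differs from compound 2 by hydroxy in place of chloro on an aromatic carbon. Among the compounds with values here, no measured pair covers a hydroxy entering; what bears on the change is the departure of chloro, the reverse of an at least 2.0-fold lower number from compound 1 to compound 2 (0.30 log units; that floor lies within the scatter), and the parallel an at least 2.0-fold lower number from compound 1 to compound 3 (0.31 log units; beyond the scatter) points the same way for a halogen. Removing the chloro is therefore expected to raise the number, a step of a 1.8-fold higher number from compound 2 to compound 4 (0.25 log units; within the scatter), with a fair chance that only a limit is reported again. Compound 4 is estimated at 110 ug/mL, between 55 ug/mL and 220 ug/mL.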

Compound 4, half-maximal cytotoxic concentration: 98 ug/mL
Estimate against measurement, compound 4: 1.1-fold (0.05 log units) above; measured number inside the range.
By their numbers in this assay, from the lowest: compounds 3, 2 and 4 (each within the scatter of the next). At a limit, above all of these: compound 1.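

On an aromatic carbon meta to a large group, hydroxy is the only group shown here that is not a halogen, and in this assay its exchange for chloro gives a 1.6-fold higher number from compound 2 to compound 4 (0.20 log units; within the scatter), so compound 4 cannot be told apart from compound 2. Against hydrogen the step is an at least 1.2-fold lower number from compound 1 to compound 4 (0.10 log units; that floor lies within the scatter), which shows no separation from the unsubstituted compound either. Compound 1 gives only a limit, so the full size of that step stays unknown: the limit of > 125 ug/mL in this assay, at which 1 of the 4 values shown sits.

Going by these compounds, whether an amine or a methoxy group on the same carbon would stay within the scatter of hydroxy remains open.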